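Removing One Methoxy Group From a Pyrazole Chalcone Core

The source may hold more compounds than are shown below. What is called first, only, known or untested is meant among the compounds shown, and "the series" means these compounds.

In a functional assay on M14 cells (Homo sapiens) for cytotoxicity, read by sulforhodamine B assay, with a stated time of 48 h, tested at 1 uM (on this read-out higher numbers stand for a weaker effect at the one concentration tested and lower numbers for a stronger effect), compound 1, with structure `COc1cc(-c2cc(/C=C/C(=O)c3ccc(N)cc3)[nH]n2)cc(OC)c1OC`, gives 90%. Compound 2, with structure `COc1ccc(-c2cc(/C=C/C(=O)c3ccc(N)cc3)[nH]n2)cc1OC`, shares its core and differs by a single change, described as hydrogen in place of methoxy on an aromatic carbon; in this assay compound 2 gives 101%, and the step of a number 11 percentage points higher from compound 1 to compound 2 (beyond the scatter) is modest but beyond the usual scatter. Compound 3, with structure `COc1cc(C(=O)/C=C/c2cc(-c3cc(OC)c(OC)c(OC)c3)n[nH]2)cc(OC)c1OC`, has a different core, and how its core differs from that of compound 1 is not broken down here; in this assay compound 3 gives 98%, a number that lies within the scatter of the value for compound 2 and also within the scatter of the value for compound 1. Compound 4, with structure `COc1ccc(-c2cc(/C=C/C(=O)c3cc(OC)c(OC)c(OC)c3)[nH]n2)cc1OC`, has not been measured. It differs from compound 3 by hydrogen in place of methoxy on an aromatic carbon, and since the place described is the same word for word as for compound 2, this is the same change as before. The step of a number 7 percentage points higher from compound 3 to compound 4 (within the scatter) is therefore expected to resemble the measured step of a number 11 percentage points higher from compound 1 to compound 2 (beyond the scatter), and compound 4 is estimated to give 105%, with a range from 94% to 116%.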

Compound 4, a percentage reported as activity, at one concentration (the size of the read-out at that concentration, not a potency): 91%
Estimate against measurement, compound 4: 14 percentage points above; measured number below the stated range.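

Putting hydrogen in place of methoxy on an aromatic carbon gives a number 7 percentage points lower from compound 3 to compound 4 (within the scatter) in this assay, a step too small to count as a real change on its own. Set beside the earlier step, the same change does not carry over cleanly from one core to the other: the same change on two cores in this assay, a number 11 percentage points higher (beyond the scatter) from compound 1 to compound 2 and a number 7 percentage points lower (within the scatter) from compound 3 to compound 4, 18 percentage points apart, beyond the scatter of two such steps

This shows that the result on the core of compound 1 cannot simply be transferred to another core in this series, but two pairs of compounds, read at one concentration, do not show why the cores part ways or what the change would do on a third core.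

The compounds shown carry only methoxy or hydrogen at this place, so what a hydroxyl group, a fluorine atom or a longer alkoxy chain would do there stays open. Also open, going by these compounds, is whether the two cores would still differ in this way at other concentrations.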